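This account rests on a few compounds, and the source may have more. Where it says the series, first, only, none or still open, it means among the compounds named here.

Measured compounds:
- compound 1, `N#Cc1ccc(-c2nnc(-c3ccc(S(N)(=O)=O)cc3)o2)cc1`, 318 nM in an assay on cells for inhibition of Amine oxidase [flavin-containing] B (Homo sapiens), read by fluorescence and spectrophotometry, using microsomes, with a stated time of 20 min; on this read-out higher numbers stand for weaker inhibition and lower numbers for stronger inhibition
- compound 2, `NS(=O)(=O)c1ccc(C(=O)NNC(=O)c2ccc(Cl)c(Cl)c2)cc1`, 10100 nM in this assay

Of the two numbers recorded so far, compound 1 has the lower one; the nearest value, that of compound 2, is higher by a gap that lies well beyond the usual scatter of this read-out. Among the measured compounds shown here, no step between two measured compounds that differ in a single place is available, so any expectation for a new compound rests on compound 1 alone. Compound 3, `NS(=O)(=O)c1ccc(-c2nnc(-c3ccccc3)o2)cc1`, differs from compound 1 in one place: hydrogen in place of cyano on an aromatic carbon, on an aromatic carbon of a six-membered aromatic ring of carbon only, para to a large group. For the measured compounds named here, since no comparable step has been measured, the expectation for the step of a 2.5-fold higher number from compound 1 to compound 3 (0.40 log units; beyond the scatter) is a modest move towards a higher number, not far beyond the scatter. Compound 3 is thus estimated at 800 nM, with a range from 250 nM to 2500 nM.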

Compound 3, half-maximal inhibitory concentration: 168 nM
Beside the measured number, compound 3's estimate is 4.8-fold (0.68 log units) above it, outside the stated range (below it).
By their numbers in this assay, from the lowest: compounds 3 and 1 (each within the scatter of the next); then compound 2.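

In this assay, putting hydrogen in place of cyano on an aromatic carbon, para to a large group, gives a 1.9-fold lower number from compound 1 to compound 3 (0.28 log units; within the scatter). This shows that, on this one step, the read-out does not separate the cyano compound from the unsubstituted one, so the cyano group, with its triple bond and hydrogen-bond acceptor, is not required at this position for a value of this order. Nothing measured alongside these numbers accounts for this result.

Hydrogen is the only replacement for cyano shown, so what an amine, a carboxylic acid or a methoxy group would do on the same aromatic carbon remains open. Going by these compounds, whether this step would read the same way on a different core also remains open.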